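Heteroaryl swap on the shared core: compound 3 to compound 4

The source may hold more compounds than are shown below. What is called first, only, known or untested is meant among the compounds shown, and "the series" means these compounds.

Compound 3 `Cn1ncnc1-c1ccccc1-c1ccc(CN2C(=O)[C@H](NC(=O)CC(C)(C)N)CCc3ccccc32)cc1` gives the lowest number in the set in a functional assay (Pituitary gland cell) with Rattus norvegicus as the target (a lower number here means that less compound is needed, a higher number that more compound is needed for the effect), with 265 nM. Compound 2 `Cc1noc(-c2ccccc2-c2ccc(CN3C(=O)[C@H](NC(=O)CC(C)(C)N)CCc4ccccc43)cc2)n1` gives 1050 nM and compound 1 `CC(C)(N)CC(=O)N[C@@H]1CCc2ccccc2N(Cc2ccc(-c3ccccc3C(=O)O)cc2)C1=O` gives 2500 nM; the steps of a 2.4-fold lower number from compound 1 to compound 2 (0.38 log units; beyond the scatter), a 9.4-fold lower number from compound 1 to compound 3 (0.97 log units; beyond the scatter) and a 4.0-fold lower number from compound 2 to compound 3 (0.60 log units; beyond the scatter) were all modest yet beyond the scatter. Compound 4 `COc1nsnc1-c1ccccc1-c1ccc(CN2C(=O)[C@H](NC(=O)CC(C)(C)N)CCc3ccccc32)cc1` carries a group of 7 heavy atoms (3 carbon, 2 nitrogen, 1 oxygen, 1 sulfur; one five-membered aromatic ring with 3 hetero atoms) in place of a group of 6 heavy atoms (3 carbon, 3 nitrogen; one five-membered aromatic ring with 3 hetero atoms), on an aromatic carbon. For the measured compounds named here, the only measured step of the same kind, one five-membered heteroaryl for another on that carbon, is a 4.0-fold lower number from compound 2 to compound 3 (0.60 log units; beyond the scatter); no measured pair contains this entering group, so the direction is open. For compound 4 a modest step in this assay is expected, a 1.9-fold higher number from compound 3 to compound 4 (0.28 log units; within the scatter), more likely toward a somewhat higher number. Compound 4 is estimated at 500 nM, within 150 nM to 1600 nM.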

Compound 4, half-maximal effective concentration: 1800 nM
Beside the measured number, compound 4's estimate is 3.6-fold (0.56 log units) below it; the measured number lies above the stated range.
By their numbers in this assay, from the lowest: compound 3; then compounds 2, 4 and 1 (each within the scatter of the next, the first and the last beyond it).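

In this assay, a five-membered aromatic ring with 3 hetero atoms on this aromatic carbon, ortho to a large group, is not interchangeable: the swap gives a 6.8-fold higher number from compound 3 to compound 4 (0.83 log units; beyond the scatter). The steps of a 1.7-fold higher number from compound 2 to compound 4 (0.23 log units; within the scatter) and a 1.4-fold lower number from compound 1 to compound 4 (0.14 log units; within the scatter) both lie within the scatter, so a heteroaryl here does not by itself bring the number clear of the carboxy value. No supporting measurement accompanies these steps, and the gap stays unexplained. Open, as far as these compounds go, is whether a tetrazole, or a triazole without the methyl, would hold the number of compound 3.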